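1H-pyrazol-4-yl for 3-fluorophenyl on the shared core

A few compounds are considered here, and "the series" means these few. Any claim that something is new, unique, unknown or untested is made for them only; others in the source may bear on it.

Half-maximal effective concentrations measured so far in an ADME assay on THP-1 cells (Homo sapiens) for cytotoxicity, read by MTT assay, with a stated time of 72 h (a higher number here means that more compound is needed for the effect, a lower number that less compound is needed), are as follows.
- compound 1 `CN(C)c1ccc(-c2ccc3[nH]c(=O)nc(-c4ccccc4)c3c2)cn1` gives > 50000 nM as a limit
- compound 2 `O=c1nc(-c2ccccc2)c2cc(-c3cccc(F)c3)ccc2[nH]1` gives > 50000 nM as a limit
- compound 3 `CNC(=O)c1cccc(-c2ccc3[nH]c(=O)nc(-c4ccccc4)c3c2)c1` gives > 50000 nM as a limit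

Compound 2 stands at > 50000 nM in this assay and this is a limit of the assay, not a number. The two other values are limits as well, so compound 2 has no readable rank among them.

The change to compound 4 `O=c1nc(-c2ccccc2)c2cc(-c3cn[nH]c3)ccc2[nH]1` puts 1H-pyrazol-4-yl in place of 3-fluorophenyl on an aromatic carbon and leaves the shared core as it is.

Going by the values given here, the only measured step from compound 2 is a step that the two limits leave unreadable from compound 2 to compound 3 and it gives no size to carry over. The wider evidence is the limit of > 50000 nM in this assay, at which 3 of the 3 values shown sit, and no compound shown goes against it. Among the compounds with values here, no step beyond the scatter is therefore expected in this assay and no direction can be given, since the expectation rests on a step that the two limits leave unreadable from compound 2 to compound 3 as its only step. The step expected here is a number no higher from compound 2 to compound 4 (the limit leaves the size open) as an estimate. For compound 4 the estimate is 50000 nM with an expected range from 20000 nM to 100000 nM and a report as a limit is the likeliest outcome.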

Compound 4, half-maximal effective concentration: > 50000 nM
Compound 4 gave a limit, no number; the forecaster's own chance of this, stated with the estimate: 80%; the middle value lies on the limit itself.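

In this assay, going by these compounds alone, compound 4 gives > 50000 nM, a limit of the assay and not a number; compound 2 also stands at a limit, so no step between the two can be read. The series rests on one limit: the limit of > 50000 nM in this assay, at which 4 of the 4 values shown sit.

The compounds shown leave open how 1H-pyrazol-4-yl and 3-fluorophenyl on the shared core compare in this assay.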